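From 4-fluorophenyl to methyl in compound 1

The source may report more compounds than this note shows. Statements on the series, on what has been measured and on what is new or still open speak of the compounds shown alone.

Among the compounds with values here, in a physicochemical assay for solubility, read by HPLC, in phosphate buffer, measured as kinetic solubility, with a stated time of 1 h, at pH 7.4, tested at 250 uM (a lower number here means a less soluble compound, a higher number a more soluble compound), compound 1 (`CN1CCC(c2ccc3c(c2)oc(=O)n3C(=O)NCCCCc2ccc(F)cc2)CC1`) gives 22000 nM and is the only compound with a number. Compound 2 (`CCN1CCN(c2ccc3c(c2)oc(=O)n3C(=O)NCCCCc2ccccc2)CC1`) gives < 1000 nM which is a limit. Compound 3 (`CN1CCN(c2ccc3c(c2)oc(=O)n3C(=O)NCCCCc2ccccc2)CC1=O`) gives < 1000 nM which is also a limit. Against compound 1 stands only the limit of < 1000 nM in this assay, at which 2 of the 3 values shown sit, with no second number.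

Compound 4 (`CCCCCNC(=O)n1c(=O)oc2cc(C3CCN(C)CC3)ccc21`) carries the change methyl in place of 4-fluorophenyl on a saturated chain carbon, four bonds along the chain from an amide-type nitrogen. Within the data shown here, the only measured step is a step that the two limits leave unreadable from compound 2 to compound 3 and it offers no size to carry over, since it lies at a different place. The expectation rests on compound 1 at 22000 nM and on the structural change alone. An upward step is expected, estimated as a 2.7-fold higher number from compound 1 to compound 4 (0.44 log units; beyond the scatter) and held loosely. Compound 4 is estimated at 60000 nM with an expected range from 15000 nM to 200000 nM in this read-out.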

Compound 4, solubility: 240000 nM
For compound 4 the middle estimate is 4.0-fold (0.60 log units) below the measured one; the measured number lies above the stated range.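

In this assay, methyl in place of 4-fluorophenyl on a saturated chain carbon, four bonds along the chain from an amide-type nitrogen, gives an 11-fold higher number from compound 1 to compound 4 (1.04 log units; beyond the scatter). Within the data shown here, this is the first readable step and shows that this position can move the read-out by a large margin; the earlier step cannot be read. Compound 2 and compound 3 remain limits, not numbers: the limit of < 1000 nM in this assay, at which 2 of the 4 values shown sit.

Still open, as far as these compounds go, is whether the step follows from losing the fluorine or the whole aromatic ring. An amine or a carboxylic acid at this position also remains untested in the compounds shown.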